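One group exchanged on the shared core

The compounds below may be only part of what the source reports. "The series", "measured", "known", "first", "only" and "open" are said of these compounds alone.

Values measured in a physicochemical assay for solubility, in phosphate buffer, at pH 7.4 (a higher number here means a more soluble compound, a lower number a less soluble compound), follow
- compound 1 `CC(=O)N[C@@H]1CCC[C@H](C(=O)Nc2cc(-c3cnn(C)c3C)c(Cl)cn2)C1` gives 960000 nM
- compound 2 `CC(=O)N[C@@H]1CCC[C@H](C(=O)Nc2cc(-c3cnn4ccccc34)c(Cl)cn2)C1` gives 45000 nM
- compound 3 `CC(=O)N[C@@H]1CCC[C@H](C(=O)Nc2cc(-c3nnn4ccccc34)c(Cl)cn2)C1` gives 530000 nM

Compound 3, at 530000 nM in this assay, stands level with compound 1 within the scatter, and clearly apart from compound 2. The next compound, compound 4 `CC(=O)N[C@@H]1CCC[C@H](C(=O)Nc2cc(-c3cnn4c3COCC4)c(Cl)cn2)C1`, departs from compound 3 as follows: a group of 9 heavy atoms (6 carbon, 2 nitrogen, 1 oxygen; one five-membered aromatic ring with 2 hetero atoms, one six-membered non-aromatic ring with 2 hetero atoms) in place of a group of 9 heavy atoms (6 carbon, 3 nitrogen; one five-membered aromatic ring with 3 hetero atoms, one six-membered aromatic ring with 1 hetero atom), on an aromatic carbon. It keeps a five-membered aromatic ring with 2 hetero atoms, as compound 1 and compound 2 do, but it lacks the six-membered aromatic ring with 1 hetero atom found in compound 2 and compound 3.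

For the measured compounds named here, three measured steps bear on this change. Two were large, a 21-fold lower number from compound 1 to compound 2 (1.33 log units; beyond the scatter) and a 12-fold higher number from compound 2 to compound 3 (1.07 log units; beyond the scatter), and both involve compound 2. The third, a 1.8-fold lower number from compound 1 to compound 3 (0.26 log units; within the scatter), stays within the scatter. Going by the values given here, compound 2 thus stands alone at the low end, and no measured compound carries the new six-membered non-aromatic ring with 2 hetero atoms, so a fall cannot be ruled out. The more likely outcome is a value close to the other two. Expected here is a 1.1-fold lower number from compound 3 to compound 4 (0.03 log units; within the scatter) and thus no step beyond the scatter. Compound 4 is estimated at 500000 nM (expected range 170000 nM to 1000000 nM).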

Compound 4, solubility: 220000 nM
Compound 4: the middle estimate sits 2.3-fold (0.36 log units) above what was measured; low and high end bracket the measured number.
By their numbers in this assay, from the lowest: compound 2; then compound 4; then compounds 3 and 1 (each within the scatter of the next).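

In this assay, the exchange at this position gives a 2.4-fold lower number from compound 3 to compound 4 (0.38 log units; beyond the scatter), and it also gives a 4.4-fold lower number from compound 1 to compound 4 (0.64 log units; beyond the scatter) and a 4.9-fold higher number from compound 2 to compound 4 (0.69 log units; beyond the scatter), so compound 4 occupies a level of its own between compound 2 and the pair formed by compound 1 and compound 3. The groups exchanged between compound 3 and compound 4 match in heavy atoms, hydrogen-bond donors, hydrogen-bond acceptors and net charge, so at this position on the aromatic carbon these counts alone do not fix the number, and compound 2 and compound 3 had already hinted at this. Neither does the presence of a fused second ring give a simple order, as compound 1 lacks one and compound 4 carries a non-aromatic one, and nothing measured on these compounds explains the differences among them.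

Compound 4 is the only one shown with a six-membered non-aromatic ring with 2 hetero atoms, so the contribution of its ring oxygen cannot be separated from that of the ring as a whole. Going by these compounds, it also remains open how the number would respond to an amine or a carboxylic acid on the five-membered aromatic ring, or to a longer chain in place of the methyl groups of compound 1.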